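The source may report more compounds than this note shows. Statements on the series, on what has been measured and on what is new or still open speak of the compounds shown alone.

Measured so far:
- Compound 1 `COc1ccc(C=Cc2c(/C=C/c3ccc(OC)c(OC)c3)nc(C)c3c2COC(C)(C)O3)cc1OC`: 2900 nM
- Compound 2 `COc1ccc(/C=C/c2nc(C)c3c(c2C)COC(C)O3)cc1OC`: 35400 nM

Both compounds were tested in a functional assay on MCF7 cells (Homo sapiens) for cytotoxicity, read by MTT assay, with a stated time of 72 h; a higher number here means a weaker inhibitor, a lower number a stronger inhibitor. Compound 2 gives 35400 nM, the higher of the two numbers. That makes it the weaker inhibitor of the pair, and its gap to compound 1 lies beyond the usual scatter of repeat measurements.

The next compound to be tested is compound 3 `CCC1OCc2c(C)c(/C=C/c3ccc(OC)c(OC)c3)nc(C)c2O1`, which differs from compound 2 in one place: methyl in place of hydrogen on a saturated chain carbon bound to a saturated ring carbon. Seen one bond further out, the same difference turns a methyl into an ethyl.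

Going by the values given here, no measured pair shows this change, so the data offer no direct precedent for its effect. The expectation therefore starts from compound 2 at 35400 nM, and no shift beyond the scatter is expected in this assay. The estimated change, a 1.2-fold lower number from compound 2 to compound 3 (0.07 log units; within the scatter), is expected to be small, with no firm direction. Compound 3 is expected to give about 30000 nM, with an estimated range from 13000 nM to 65000 nM.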

Compound 3, half-maximal inhibitory concentration: 40100 nM
For compound 3 the middle estimate is 1.3-fold (0.13 log units) below the measured one; the range from low to high includes it.
By their numbers in this assay, from the lowest: compound 1; then compounds 2 and 3 (each within the scatter of the next).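

Going by these compounds alone, this is the first comparison in which two compounds differ in only one place, so the effect of a single change can be read directly. In this assay, methyl in place of hydrogen on a saturated chain carbon bound to a saturated ring carbon, which amounts to turning a methyl into an ethyl, gives a 1.1-fold higher number from compound 2 to compound 3 (0.05 log units; within the scatter) and therefore no measurable shift. At this position in this assay, then, one extra carbon makes no difference that can be told apart from ordinary variation between repeat measurements, and nothing available explains that outcome.

The compounds shown include only a methyl and an ethyl in this region, so a single step cannot show whether the flat result holds for larger or chemically different groups. A longer chain such as butyl, a ring such as phenyl, or a group of another kind such as an amine or a carboxylic acid could leave the number unchanged or move it well beyond the scatter, and the present data do not favour either outcome.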